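The compounds below may be only part of what the source reports. "The series", "measured", "known", "first", "only" and "open" are said of these compounds alone.

Working notes on the series, read in an ADME assay on microsomes from liver (Homo sapiens) for metabolic stability, with a stated time of 60 min, tested at 1 uM; on this read-out higher numbers stand for a more stable compound and lower numbers for a less stable compound. Three measured compounds differ only in the aryl group on a saturated chain carbon bound to an amide-type nitrogen in a ring: compound 1 `CS(=O)(=O)Nc1ccc2c(c1)S(=O)(=O)N=C(C1=C(O)[C@@H]3[C@H]4CC[C@H](C4)[C@@H]3N(Cc3ccccc3F)C1=O)N2`, compound 2 `COc1cccc(CN2C(=O)C(C3=NS(=O)(=O)c4cc(NS(C)(=O)=O)ccc4N3)=C(O)[C@@H]3[C@H]4CC[C@H](C4)[C@@H]32)c1` and compound 3 `CS(=O)(=O)Nc1ccc2c(c1)S(=O)(=O)N=C(C1=C(O)[C@@H]3[C@H]4CC[C@H](C4)[C@@H]3N(Cc3ccc(F)c(Cl)c3)C1=O)N2`. Compound 1 gives 89%, compound 3 gives 87%, and compound 2 gives 61%, the lowest of the three numbers.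

Compound 4 `COc1cccc(CN2C(=O)C(C3=NS(=O)(=O)c4cc(NS(C)(=O)=O)ccc4N3)=C(O)[C@@H]3[C@@H]4CC[C@@H](C4)[C@@H]32)c1` keeps the 3-methoxyphenyl of compound 2 and has the same atoms and bonds, differing only in configuration as drawn: the two compounds have the same atoms and bonds and differ only in configuration as drawn: 2 of 4 stereo elements differ; a stereocentre at a saturated ring carbon is drawn S in compound 2 and R in compound 4; a stereocentre at a saturated ring carbon is drawn R in compound 2 and S in compound 4.

The measured steps bear on this only indirectly. The aryl changes give a number 28 percentage points lower from compound 1 to compound 2 (beyond the scatter) and a number 26 percentage points higher from compound 2 to compound 3 (beyond the scatter), both modest and beyond the scatter, while a number 2 percentage points lower from compound 1 to compound 3 (within the scatter) stays within it. Within the data shown here, none of them changes configuration, so no measured pair shows the effect of the change at the saturated ring carbons, and no direction can be supported. The modest steps serve only as a scale for how far this assay can move in this series. The expected outcome is therefore no step beyond the scatter, estimated as a number 1 percentage points lower from compound 2 to compound 4 (within the scatter), with a shift of modest size in either direction left open. For compound 4 the estimated value is 60%, with an expected range from 40% to 80%.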

Compound 4, percent of the compound remaining: 83%
Compound 4: middle estimate off by 23 percentage points, on the low side, and the stated range ends below it.
By their numbers in this assay, from the lowest: compound 2; then compounds 4, 3 and 1 (each within the scatter of the next).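

In this assay the configuration at the saturated ring carbons proves to be a lever in its own right: with the 3-methoxyphenyl group kept, the step is a number 22 percentage points higher from compound 2 to compound 4 (beyond the scatter). This step is of the same modest class as the aryl steps beyond the scatter, so the low number of compound 2 cannot be read as a property of the 3-methoxyphenyl group alone; the aryl comparisons among compound 1, compound 2 and compound 3 hold for one drawn configuration only. The step can be assigned to configuration and to nothing else, because no atom or bond changes: the fact that compounds 2 and 4 differ only in the configuration as drawn

Since both stereocentres change together, the compounds shown do not tell which of the two carries the step, nor whether the 2-fluorophenyl of compound 1 or the 3-chloro-4-fluorophenyl of compound 3 would respond to the same change in configuration. Also open, on these data alone, is how the drawn configuration of compound 4 would behave with a group of another kind in place of the aryl ring, such as a longer alkyl chain or a carboxylic acid.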